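This account rests on a few compounds, and the source may have more. Where it says the series, first, only, none or still open, it means among the compounds named here.

Compound 1, `CCC(C)c1cc(C)c(C(=O)N=C(N)N)cc1S(C)(=O)=O`: 8 nM
Compound 2, `Cc1c(C(=O)N=C(N)N)cc(S(C)(=O)=O)c(C)c1C`: 55 nM

In a functional assay for inhibition of sodium/hydrogen exchanger (Oryctolagus cuniculus) (on this read-out higher numbers stand for weaker inhibition and lower numbers for stronger inhibition), compound 1 gives 8 nM, the lowest of the two numbers shown. Compound 2 gives 55 nM, a higher number, and the gap between the two lies beyond the usual scatter. Compound 3, `Cc1cc(OCc2ccccc2)c(S(C)(=O)=O)cc1C(=O)N=C(N)N`, has not yet been measured in this assay. It differs from compound 1 in a single place: benzyloxy in place of sec-butyl on an aromatic carbon. The change sits ortho to a methylsulfonyl group and para to a group of 6 heavy atoms on the shared core. Among the measured compounds shown here, no pair of measured compounds that differ in one place is available, so there is no measured step of this kind to lean on. Compound 3 is expected to show a small step toward a higher number, a 2.5-fold higher number from compound 1 to compound 3 (0.40 log units; beyond the scatter), which may not reach beyond the scatter. The estimate for compound 3 in this assay is 20 nM, with a range from 5 nM to 80 nM.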

Compound 3, half-maximal inhibitory concentration: 28 nM
Compound 3: the middle estimate sits 1.4-fold (0.15 log units) below what was measured; low and high end bracket the measured number.
By their numbers in this assay, from the lowest: compound 1; then compounds 3 and 2 (each within the scatter of the next).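

In this assay, replacing sec-butyl with benzyloxy on the aromatic carbon ortho to the methylsulfonyl group gives a 3.5-fold higher number from compound 1 to compound 3 (0.54 log units; beyond the scatter) and counts as a modest step beyond the scatter. Among the compounds shown here, this is the only measured step at this place, and it shows that the position can carry a group of 8 heavy atoms with a six-membered aromatic ring, as compound 3 still gives 28 nM in this assay and remains a nanomolar inhibitor. The oxygen and the ring enter together, so the shares of each in the step cannot be separated. As far as these compounds go, it remains open how a methoxy group, an amine or a longer chain would read at this place. Nothing at hand bears on why the number moves as it does.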